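Swapping the Amide Heteroaryl Group: Expected Lipophilicity

The source may hold more compounds than are shown below. What is called first, only, known or untested is meant among the compounds shown, and "the series" means these compounds.

Three compounds have been measured in a physicochemical assay for lipophilicity, read by HPLC, in phosphate buffer, measured as octanol-water partition, with a stated time of 1 h, at pH 7.4; on this read-out lower numbers stand for lower lipophilicity and higher numbers for higher lipophilicity:
compound 1 `C[C@@]1(c2cc(NC(=O)c3coc(C(F)F)n3)ccc2F)C=C(CF)OC(N)=N1` gives 2.6
compound 2 `C[C@@]1(c2cc(NC(=O)c3cnc(C(F)F)cn3)ccc2F)C=C(CF)OC(N)=N1` gives 2.5
compound 3 `C[C@@]1(c2cc(NC(=O)c3ncc(C#N)cc3Cl)ccc2F)C=C(CF)OC(N)=N1` gives 2.5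

All three share one core and differ only in the aromatic group attached to the amide carbonyl. Compound 1 has the highest of the three numbers, but its lead is slight: a number 0.10 log units lower from compound 1 to compound 2 (within the scatter) and a number 0.10 log units lower from compound 1 to compound 3 (within the scatter), and between the other two no change at the digits printed from compound 2 to compound 3 (within the scatter). In short, the three groups tried so far leave this assay essentially unchanged.

Compound 4 `C[C@@]1(c2cc(NC(=O)c3ccc(C#N)cn3)ccc2F)C=C(CF)OC(N)=N1` is the next step from compound 1. The change is 5-cyanopyridin-2-yl in place of 2-(difluoromethyl)-1,3-oxazol-4-yl on a carbonyl carbon. The entering group shares its nitrile with the 3-chloro-5-cyanopyridin-2-yl of compound 3, but lacks the chlorine, and it is a six-membered ring with one hetero atom in place of a five-membered ring with two. The measured steps bearing on this exchange were all within the scatter, so they give no sign that a heteroaryl swap of this kind moves the number far. Even so, a modest drop is expected for compound 4, with a number 0.60 log units lower from compound 1 to compound 4 (beyond the scatter). Compound 4 is therefore estimated at 2, within a range of 1.6 to 2.4.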

Compound 4, distribution coefficient: 2.3
Beside the measured number, compound 4's estimate is 0.30 log units below it; the range from low to high includes it.
By their numbers in this assay, from the lowest: compounds 4, 2, 3 and 1 (each within the scatter of the next).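

Compound 4 extends the flat picture to a fourth group on the carbonyl carbon in this assay: the 5-cyanopyridin-2-yl group gives a number 0.30 log units lower from compound 1 to compound 4 (within the scatter) and a number 0.20 log units lower from compound 2 to compound 4 (within the scatter), so this six-membered ring with one hetero atom stands level, within error, with both the five-membered ring of compound 1 and the pyrazine ring of compound 2. The new information is the single-atom exchange, hydrogen in place of chloro on an aromatic carbon, which gives a number 0.20 log units lower from compound 3 to compound 4 (within the scatter), so on this ring the chlorine can be removed without a step that exceeds the scatter. Nothing offered here accounts for these numbers or ties them to any feature of the groups.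

All four groups at this place are aromatic rings, so it remains open whether a saturated amine, a carboxylic acid or a plain alkyl chain on the carbonyl carbon would also stay within the scatter of these compounds. Going by these compounds, it is also open whether hydrogen in place of chloro would read the same on the other rings, such as the 2-(difluoromethyl)-1,3-oxazol-4-yl of compound 1.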